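Chain variation at the core of an aminopyridine series

The source may hold more compounds than are shown below. What is called first, only, known or untested is meant among the compounds shown, and "the series" means these compounds.

Measured so far:
compound 1 `COC(C)Cc1cc(C)cc(N)n1`: > 5000 nM
compound 2 `CC(C)=Cc1cc(C)cc(N)n1`: 685 nM

In an assay on isolated protein for inhibition of Nitric oxide synthase, inducible (Homo sapiens), with a stated time of 30 min (a higher number here means a weaker inhibitor, a lower number a stronger inhibitor), compound 1 gives only > 5000 nM, which is a limit of the assay and not a number. Of the two values recorded, one sits at that limit (the limit of > 5000 nM in this assay, at which 1 of the 2 values shown sits), so compound 1 stands at the weak end of what has been measured. Compound 2 gives 685 nM in this assay, a measured number.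

Compound 3 `CSCCC(C)Cc1cc(C)cc(N)n1` is not yet measured. It differs from compound 1 by 2-(methylsulfanyl)ethyl in place of methoxy on a saturated chain carbon bound to two saturated chain carbons. Within the data shown here, no measured pair isolates this change, so the size of the step is open. The expectation for compound 3 is a move toward stronger inhibition, beyond the scatter, with a step of an at least 3.3-fold lower number from compound 1 to compound 3 (0.52 log units; beyond the scatter) in this assay. Compound 3 is estimated at 1500 nM, with a range from 300 nM to 5000 nM.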

Compound 3, half-maximal inhibitory concentration: > 5000 nM
Compound 3: a limit, no number (the forecaster's own chance of this, stated with the estimate: 25%); middle value at least 3.3-fold (0.52 log units) from the limit.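

In this assay compound 3 gives > 5000 nM, a limit of the assay and not a number. Among these compounds, compound 1 also stands at a limit, so no step between compound 1 and compound 3 can be read. On these data alone, whether 2-(methylsulfanyl)ethyl in place of methoxy changes inhibition at all remains open.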